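Swapping fluoro for methoxy on the benzyl arm

The source may hold more compounds than are shown below. What is called first, only, known or untested is meant among the compounds shown, and "the series" means these compounds.

For the measured compounds named here, the three compounds measured so far share one core and differ only in the benzyl group attached to the ring nitrogen. Compound 1 `Nc1cc(N)c2nc(-c3ccccc3)c(NCc3ccc(Cl)c(Cl)c3)nc2c1` carries a 3,4-dichlorophenyl and, in a functional assay on PC-3 cells (Homo sapiens) for inhibition, read by sulforhodamine B assay, with a stated time of 48 h (a lower number here means a stronger inhibitor of growth, a higher number a weaker inhibitor of growth), compound 1 gives 5130 nM. Compound 2 `COc1ccc(CNc2nc3cc(N)cc(N)c3nc2-c2ccccc2)cc1OC` carries a 3,4-dimethoxyphenyl and compound 2 gives 27500 nM. Compound 3 `Nc1cc(N)c2nc(-c3ccccc3)c(NCc3ccc(F)cc3)nc2c1` carries a 4-fluorophenyl and compound 3 gives 15500 nM, the second highest of the three numbers; the measured steps are a 5.4-fold higher number from compound 1 to compound 2 (0.73 log units; beyond the scatter), a 3.0-fold higher number from compound 1 to compound 3 (0.48 log units; beyond the scatter) and a 1.8-fold lower number from compound 2 to compound 3 (0.25 log units; within the scatter).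

Compound 4 `COc1ccc(CNc2nc3cc(N)cc(N)c3nc2-c2ccccc2)cc1` is the next member, differing from compound 3 in one place: methoxy in place of fluoro on an aromatic carbon. The step that bears on this change most directly is a 1.8-fold lower number from compound 2 to compound 3 (0.25 log units; within the scatter), which lies within the scatter, so replacing a fluoro with a methoxy-bearing ring has not so far moved the number meaningfully. The larger step of a 5.4-fold higher number from compound 1 to compound 2 (0.73 log units; beyond the scatter) concerns the dichloro compound and not compound 3, so it carries less weight here.

Compound 4 is therefore expected to give a number close to that of compound 3, with the estimated step being a 1.3-fold higher number from compound 3 to compound 4 (0.11 log units; within the scatter). The estimate for compound 4 is 20000 nM, within the range 8000 nM to 50000 nM.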

Compound 4, concentration for total growth inhibition: 27500 nM
The estimate for compound 4 lay 1.4-fold (0.14 log units) below the measured number; the measured number falls inside the stated range.
By their numbers in this assay, from the lowest: compound 1; then compounds 3, 2 and 4 (each within the scatter of the next).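

In this assay, the exchange made directly at the aromatic carbon para to a large group, a 1.8-fold higher number from compound 3 to compound 4 (0.25 log units; within the scatter), stays within the scatter, and removing one methoxy, no change at the digits printed from compound 2 to compound 4 (within the scatter), does not separate the mono- and dimethoxy compounds either, so compounds 2, 3 and 4 cannot be told apart by this read-out. Against this cluster, compound 1 stands alone: the exchange of its 3,4-dichlorophenyl for 4-methoxyphenyl gives a 5.4-fold higher number from compound 1 to compound 4 (0.73 log units; beyond the scatter), and its steps to compound 2 and compound 3 are also beyond the scatter, so among these four compounds only the 3,4-dichlorophenyl compound is set apart. No measurement shown here offers an explanation for this separation.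

The compounds shown leave open whether the lower number of compound 1 requires both chloro groups or would persist with a single chloro on the ring. They also leave open how an amine, a carboxylic acid or a trifluoromethyl at the same aromatic carbon would read, and whether any such group would move the number beyond the scatter from that of compound 3.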